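Working notes on a triazolylmethoxy series: compound 3 to compound 4

The source may report more compounds than this note shows. Statements on the series, on what has been measured and on what is new or still open speak of the compounds shown alone.

Measured so far:
compound 1 `O=Cc1cccc(OCc2cn(Cc3ccccc3)nn2)c1` — > 50000 nM
compound 2 `O=C1Nc2ccc(Cl)cc2/C1=C/c1cccc(OCc2cn(Cc3ccccc3)nn2)c1` — > 50000 nM
compound 3 `O=C1Nc2ccc([N+](=O)[O-])cc2/C1=C\c1cccc(OCc2cn(Cc3ccccc3)nn2)c1` — > 50000 nM

Every reading in a functional assay on A549 cells (Homo sapiens) for inhibition, read by MTT assay, with a stated time of 48 h (a higher number here means a weaker inhibitor, a lower number a stronger inhibitor), is a limit of the assay and not a number; (the limit of > 50000 nM in this assay, at which 3 of the 3 values shown sit). Compound 3 therefore stands at the limit, level with compound 1 and compound 2, and no ordering among the three can be drawn. Nothing in the data separates the aldehyde from either benzylidene product.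

Compound 4 `COc1ccc(Cc2ccc3c(c2)/C(=C\c2cccc(OCc4cn(Cc5ccccc5)nn4)c2)C(=O)N3)cc1` differs from compound 3 in one place: 4-methoxybenzyl in place of nitro on an aromatic carbon. Among the compounds with values here, no step between measured compounds exists to calibrate this change, and with all values at the limit the series gives no direction to lean on. The step from compound 3 to compound 4 in this assay is expected to be a number no higher from compound 3 to compound 4 (the limit leaves the size open), which is to say none beyond the scatter, with the reading most likely again a limit. Compound 4 is estimated at 50000 nM in this assay, with a range from 10000 nM to 150000 nM.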

Compound 4, half-maximal inhibitory concentration: > 50000 nM
Compound 4: a limit, no number; the forecaster's own chance of this, stated with the estimate: 70%; the middle value lies on the limit itself.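

No step can be read from compound 3 to compound 4, as both readings are limits of the assay and not numbers: the limit of > 50000 nM in this assay, at which 4 of the 4 values shown sit.

The compounds shown leave open how nitro and 4-methoxybenzyl compare in this assay and whether any group on the shared core gives a readable number.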